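Cytotoxicity in MT4 cells: a nitrophenyl swapped for bromomethylphenyl

The compounds below may be only part of what the source reports. "The series", "measured", "known", "first", "only" and "open" are said of these compounds alone.

Measured compounds:
compound 1 `O=C1c2ccccc2C(=O)N1CCOC(=S)N(C(=O)c1ccc([N+](=O)[O-])cc1)c1ccc(Cl)cc1`, > 100000 nM
compound 2 `Cc1ccc(N(C(=O)c2cccc([N+](=O)[O-])c2)C(=S)OCCN2C(=O)c3ccccc3C2=O)cc1`, 100000 nM
compound 3 `Cc1ccc(N(C(=O)c2ccc([N+](=O)[O-])cc2)C(=S)OCCN2C(=O)c3ccccc3C2=O)cc1`, 58000 nM

In an ADME assay on MT4 cells (Homo sapiens) for cytotoxicity, read by MTT assay (on this read-out lower numbers stand for higher toxicity in this test and higher numbers for lower toxicity in this test), compound 1 gives > 100000 nM, which is a limit of the assay rather than a number. Compound 1 therefore sits at the limit of > 100000 nM in this assay, at which 1 of the 3 values shown sits, and only a floor is known for it. Compound 2 gives 100000 nM and compound 3 gives 58000 nM; the step of a 1.7-fold lower number from compound 2 to compound 3 (0.24 log units; within the scatter) is within the scatter, as is the floor of an at least 1.7-fold lower number from compound 1 to compound 3 (0.23 log units; that floor lies within the scatter). All three values thus lie close together at the top of the measured range.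

Compound 4 `Cc1cc(C(=O)N(C(=S)OCCN2C(=O)c3ccccc3C2=O)c2ccc(Cl)cc2)ccc1Br` has not been measured. It differs from compound 1 by 4-bromo-3-methylphenyl in place of 4-nitrophenyl on a carbonyl carbon. Neither measured step touches this position: one exchanges methyl for chloro on an aromatic carbon, the other moves the nitro group on the nitrophenyl, and both stay within the scatter. No measured step therefore bears directly on the change from compound 1 to compound 4, and nothing shown points to a shift beyond the scatter in this assay.

On this basis compound 4 is expected to give about 100000 nM, with a range from 40000 nM to 250000 nM. The step from compound 1 to compound 4 is estimated as a number no higher from compound 1 to compound 4 (the limit leaves the size open), and a limit rather than a number is a plausible outcome.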

Compound 4, half-maximal cytotoxic concentration: 18000 nM
Estimate against measurement, compound 4: 5.6-fold (0.74 log units) above, outside the stated range (below it).
By their numbers in this assay, from the lowest: compound 4; then compounds 3 and 2 (each within the scatter of the next).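

In this assay, the carbonyl carbon whose other neighbour is the amide-type nitrogen proves to be a place where a change can move the read-out beyond the scatter: an at least 5.5-fold lower number from compound 1 to compound 4 (0.74 log units; beyond the scatter). The earlier step at this place only exchanged 3-nitrophenyl for 4-nitrophenyl and stayed within the scatter, whereas removing the nitrophenyl altogether in favour of 4-bromo-3-methylphenyl shows that this read-out does respond to the group carried here, with the lower number standing for higher toxicity in this test. As far as these compounds go, compound 1 is held at a limit of the assay and not at a number, so the step gives only a minimum size and its full extent stays unknown: the limit of > 100000 nM in this assay, at which 1 of the 4 values shown sits.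

The compounds shown do not separate the loss of the nitro group from the arrival of the bromine or of the methyl, and a phenyl bearing bromo alone or methyl alone would be needed to tell these apart. They also leave open how an amine or a carboxylic acid on this ring would read, and whether the step holds when methyl replaces chloro on the other aromatic ring.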